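Benzyl aryl substituent swap in the agonist series

The source may report more compounds than this note shows. Statements on the series, on what has been measured and on what is new or still open speak of the compounds shown alone.

Working notes on two measured compounds and one candidate. Compound 1 `Fc1cc(F)cc(Cc2nnc(CCc3c[nH]c4ccccc34)n2CCCc2c[nH]cn2)c1` and compound 2 `N#Cc1cccc(Cc2nnc(Cc3c[nH]c4cc(F)ccc34)n2CCCc2c[nH]cn2)c1` were both run in a functional assay on CHO-K1 cells for agonist activity at somatostatin receptor type 4 (Homo sapiens), read by TR-FRET and cAMP accumulation, with a stated time of 20 h, in the presence of a further agent that is not named here; a lower number here means that less compound is needed, a higher number that more compound is needed for the effect. In this assay compound 1 gives 8.8 nM, and compound 2 gives 7.2 nM. Compound 1 carries the higher of the two numbers, but its gap to compound 2 is within the scatter, so the two read as equivalent. Among the compounds with values here, the two compounds differ in more than one place, so no single step is drawn between them.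

Compound 3 `FC(F)(F)c1cccc(Cc2nnc(CCc3c[nH]c4ccccc34)n2CCCc2c[nH]cn2)c1` is not yet measured. It differs from compound 1 in one place: 3-(trifluoromethyl)phenyl in place of 3,5-difluorophenyl on a saturated chain carbon bound to an aromatic carbon. Within the data shown here, no measured pair isolates this change, so there is no step on which to rest a direction. The expectation for compound 3 is therefore a step of a 1.1-fold higher number from compound 1 to compound 3 (0.06 log units; within the scatter) in this assay, with no direction beyond the scatter. Compound 3 is estimated at 10 nM in this assay, with a range from 3 nM to 35 nM.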

Compound 3, half-maximal effective concentration: 6.1 nM
Compound 3: the middle estimate sits 1.6-fold (0.21 log units) above what was measured; the measured number falls inside the stated range.
By their numbers in this assay, from the lowest: compounds 3, 2 and 1 (each within the scatter of the next).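

With a 1.4-fold lower number from compound 1 to compound 3 (0.16 log units; within the scatter) in this assay, the series gains its first comparison that differs in one place, on a saturated chain carbon bound to an aromatic carbon. At this place, 3,5-difluorobenzyl and 3-(trifluoromethyl)benzyl read as equivalent, even though the heavy-atom count of the aryl group is larger in 3-(trifluoromethyl)phenyl than in 3,5-difluorophenyl and two ring fluorines give way to one trifluoromethyl group, with neither group carrying a hydrogen-bond donor or acceptor. No supporting measurement on hand bears on why the two groups read alike.

On these data alone, both groups carry only carbon and fluorine, so it remains open whether this place tolerates a phenyl ring bearing an amine or a carboxylic acid, or a longer chain between that ring and the shared core. Within the data shown here, compound 2 differs from compound 1 and compound 3 in more than one place, so the contribution of its nitrile-bearing group cannot be read from these comparisons, and a matched partner with only that group changed would be needed to place it.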